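The source may hold more compounds than are shown below. What is called first, only, known or untested is meant among the compounds shown, and "the series" means these compounds.

Of the compounds shown here, three built on one shared core have been tested in a functional assay on HeLa cells (Homo sapiens) for cytotoxicity, read by MTT assay, with a stated time of 48 h; a lower number here means a stronger inhibitor, a higher number a weaker inhibitor. Compound 1 `O=c1ccoc2cc(OCc3cn(Cc4ccccc4)nn3)ccc12` carries a plain benzyl group. In this assay compound 1 gives > 100000 nM, which is a limit of the assay and not a number. Compound 3 `O=c1ccoc2cc(OCc3cn(Cc4cccc(Cl)c4)nn3)ccc12` likewise gives > 100000 nM in this assay, again a limit. Compound 2 `O=c1ccoc2cc(OCc3cn(Cc4ccc(Cl)cc4Cl)nn3)ccc12` is the only one of the three with a measured number: in this assay compound 2 gives 80600 nM. The step of an at least 1.2-fold lower number from compound 1 to compound 2 (0.09 log units; that floor lies within the scatter) and the step of an at least 1.2-fold higher number from compound 2 to compound 3 (0.09 log units; that floor lies within the scatter) are both capped by the limit of > 100000 nM in this assay, at which 2 of the 3 values shown sit, and the step that the two limits leave unreadable from compound 1 to compound 3 cannot be read at all. Compound 4 `O=c1ccoc2cc(OCc3cn(Cc4ccccc4Cl)nn3)ccc12` differs from compound 2 by hydrogen in place of chloro on an aromatic carbon. Compounds 1 and 3 both sit at the limit of > 100000 nM in this assay, at which 2 of the 3 values shown sit, and compound 4 also lacks part of the 2,4-dichloro pattern of compound 2. The step expected from this change is a 1.6-fold higher number from compound 2 to compound 4 (0.21 log units; within the scatter), toward a weaker value. The number estimated for compound 4 is 130000 nM, with a range from 50000 nM to 350000 nM.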

Compound 4, half-maximal inhibitory concentration: > 100000 nM
Compound 4: no number, only a limit (the forecaster's own chance of this, stated with the estimate: 65%); the middle value does not contradict the limit.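

In this assay, hydrogen in place of chloro on an aromatic carbon, meta to a chloro group and para to a large group, gives an at least 1.2-fold higher number from compound 2 to compound 4 (0.09 log units; that floor lies within the scatter). The 2-chlorobenzyl group thus joins the benzyl and 3-chlorobenzyl groups in giving only a limit, and among the compounds shown only the 2,4-dichlorobenzyl group of compound 2 gives a number, though that step does not go beyond the scatter. The steps from compound 1 and from compound 3 to compound 4 cannot be read, and the reading stops at a ceiling shared by most of the compounds: the limit of > 100000 nM in this assay, at which 3 of the 4 values shown sit.

Open, from the compounds shown here alone, is how a fluoro, methoxy or nitro group would read at this same place, and whether a chloro group there without the second chloro group would give a number. Also open is whether any change to the benzyl group can give a step beyond the scatter, as none shown does.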